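Urea aryl swap on the shared core: compound 3

The source may report more compounds than this note shows. Statements on the series, on what has been measured and on what is new or still open speak of the compounds shown alone.

Measured so far:
compound 1 `COc1cc(Cl)cc(-c2nn(-c3cccc(NC(=O)Nc4cc(C(F)(F)F)cc(C(F)(F)F)c4)c3)cc2-c2ccncc2)c1` — 95%
compound 2 `COc1cc(Cl)cc(-c2nn(-c3cccc(NC(=O)Nc4ccc(Cl)c(Cl)c4)c3)cc2-c2ccncc2)c1` — 54%

In a functional assay on SK-MEL-2 cells (Homo sapiens) for inhibition, read by sulforhodamine B assay, with a stated time of 48 h, tested at 0.1 uM (a lower number here means a stronger effect, a higher number a weaker effect of the compound at the concentration tested), compound 1 gives 95%. Compound 2 gives 54% in the same test. Compound 2 thus stands lowest of the two numbers; its nearest neighbour, compound 1, lies higher by a margin beyond the scatter, so compound 2 shows the stronger effect of the two.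

For the measured compounds named here, no step between measured compounds that differ in one place is available, so the move to compound 3 `COc1cc(Cl)cc(-c2nn(-c3cccc(NC(=O)Nc4cccc(C(F)(F)F)c4)c3)cc2-c2ccncc2)c1` is read from the structures alone: 3-(trifluoromethyl)phenyl in place of 3,4-dichlorophenyl on an amide-type nitrogen. Compound 1 is the only other reference, and it carries trifluoromethyl groups on the urea aryl with the weaker read-out.

For the step from compound 2 to compound 3 a rise beyond the scatter is expected, a number 21 percentage points higher from compound 2 to compound 3 (beyond the scatter). Compound 3 is therefore estimated at 75%, within a range from 52% to 96%.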

Compound 3, a percentage reported as activity, at one concentration (the size of the read-out at that concentration, not a potency): 55%
Compound 3: the middle estimate sits 20 percentage points above what was measured; measured number inside the range.
By their numbers in this assay, from the lowest: compounds 2 and 3 (each within the scatter of the next); then compound 1.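

Read in this assay the swap of 3,4-dichlorophenyl for 3-(trifluoromethyl)phenyl on the amide-type nitrogen gives a number 1 percentage points higher from compound 2 to compound 3 (within the scatter) and so does not separate these two aryl groups. Hydrogen in place of trifluoromethyl on an aromatic carbon gives a number 40 percentage points lower from compound 1 to compound 3 (beyond the scatter) and is a large step towards a stronger effect. At this position, the difference between the weakest-reading aryl group and the other two therefore lies with the second trifluoromethyl group, while the exchange of the two chlorines for a single trifluoromethyl leaves the read-out level.

Going by these compounds, how an aryl group carrying a dimethylamino group or a carboxylic acid would read on the same nitrogen stays open. No measurement at hand explains either step.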